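A few compounds are considered here, and "the series" means these few. Any claim that something is new, unique, unknown or untested is made for them only; others in the source may bear on it.

Compound 1 `O=C1COc2ccc(-c3[nH]c(-c4ccc(C(F)(F)F)cc4)nc3-c3ccccc3)cc2N1` gives 111% in a functional assay on MV4-11 cells (Homo sapiens) for cytotoxicity, read by colorimetric assay and MTT assay, with a stated time of 3 days, tested at 1 uM; a lower number here means a stronger effect, a higher number a weaker effect of the compound at the concentration tested. Compound 2 `O=C1COc2ccc(-c3nn(-c4ccc(Br)cc4)cc3-c3ccccc3)cc2N1` gives 108%. Compound 3 `O=C1COc2ccc(-c3nn(-c4cc(Cl)cc(Cl)c4)cc3-c3ccccc3)cc2N1` gives 105%.

Compound 1 carries the highest of the three numbers, yet its gaps to compound 2 and to compound 3 both sit within the scatter, so the three compounds cannot be told apart on these data. Compound 4 `O=C1COc2ccc(-c3[nH]c(-c4ccc(Cl)cc4Cl)nc3-c3ccccc3)cc2N1` differs from compound 1 by 2,4-dichlorophenyl in place of 4-(trifluoromethyl)phenyl on an aromatic carbon. For the measured compounds named here, the only measured step, a number 3 percentage points lower from compound 2 to compound 3 (within the scatter), concerns a different core and a group on an aromatic nitrogen, and it stayed within the scatter; no step at the carbon of the core of compound 1 has been measured. The analyst therefore expects no step beyond the scatter, namely a number 4 percentage points lower from compound 1 to compound 4 (within the scatter). Compound 4 is estimated at 107%, expected to fall between 95% and 118%.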

Compound 4, a percentage reported as activity, at one concentration (the size of the read-out at that concentration, not a potency): 109%
Estimate against measurement, compound 4: 2 percentage points below; the measured number falls inside the stated range.
By their numbers in this assay, from the lowest: compounds 3, 2, 4 and 1 (each within the scatter of the next).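

The first step measured at this aromatic carbon, a number 2 percentage points lower from compound 1 to compound 4 (within the scatter), shows that in this assay 2,4-dichlorophenyl and 4-(trifluoromethyl)phenyl cannot be told apart at this place. For the compounds shown here, the earlier step within the scatter concerned an aromatic nitrogen on a different core, so this is the first such reading on the core of compound 1. Nothing measured here offers an explanation for this result.

Both groups compared are six-membered aromatic rings of carbon only. On these data alone, whether an amine or a carboxylic acid at this carbon would give a step beyond the scatter remains open.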